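Acetyl on a sugar hydroxyl: cytotoxicity notes

The compounds below may be only part of what the source reports. "The series", "measured", "known", "first", "only" and "open" are said of these compounds alone.

The compounds share one core carrying a sugar. Compound 1 `C=C[C@@](C)(CC[C@H]1C(C)=CC[C@H]2C(C)(C)CCC[C@]12C)O[C@@H]1O[C@@H](C)[C@@H](OC(C)=O)[C@H](O)[C@H]1O` has an acetyl on one of the sugar hydroxyls, and in a functional assay on SK-MEL-2 cells (Homo sapiens) for cytotoxicity, read by sulforhodamine B assay (on this read-out higher numbers stand for an effect only at larger amounts of compound and lower numbers for an effect already at smaller amounts), compound 1 gives 3.5 ug/mL. Compound 2 `C=C[C@@](C)(CC[C@H]1C(C)=CC[C@H]2C(C)(C)CCC[C@]12C)O[C@@H]1O[C@H](C)[C@H](O)[C@H](O)[C@H]1O` has the sugar with its hydroxyls free; in this assay compound 2 gives 3.5 ug/mL, level with compound 1 at the digits shown, within the scatter. On this read-out the two values do not separate a sugar with one acetyl from a sugar without.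

Compound 3 `C=C[C@@](C)(CC[C@H]1C(C)=CC[C@H]2C(C)(C)CCC[C@]12C)O[C@@H]1O[C@H](C)[C@H](OC(C)=O)[C@H](O)[C@H]1O` has not been measured. It differs from compound 2 by acetyl in place of hydrogen on an oxygen on a saturated carbon. Among the compounds with values here, no step between measured compounds covers that change on its own; what the numbers show is only that compound 1 and compound 2 match. The step of no change at the digits printed from compound 2 to compound 3 (within the scatter) is therefore expected to be no change beyond the scatter, in no particular direction. For compound 3 in this assay the estimate is 3.5 ug/mL, with an expected range from 1.8 ug/mL to 7 ug/mL.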

Compound 3, concentration for half-maximal effect: 3.4 ug/mL
Beside the measured number, compound 3's estimate is 1.0-fold (0.01 log units) above it; the measured number falls inside the stated range.
By their numbers in this assay, from the lowest: compounds 3, 1 and 2 (each within the scatter of the next).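

In this assay, acetyl in place of hydrogen on an oxygen on a saturated carbon can now be read as a single change, and it gives a 1.0-fold lower number from compound 2 to compound 3 (0.01 log units; within the scatter). Compound 1 and compound 2 could not show this alone, whereas this step shows that hydroxy to acetoxy at this position leaves the number within the scatter. A second single comparison in this assay, a 1.0-fold lower number from compound 1 to compound 3 (0.01 log units; within the scatter), keeps the acetoxy group in place and likewise stays within the scatter, and the only difference it tests is stated as follows: the fact that compounds 1 and 3 differ only in the configuration as drawn

As far as these compounds go, whether a longer chain such as butanoyl, an aromatic ester such as benzoyl, or a group carrying an amine or a carboxylic acid on this oxygen would also stay within the scatter of compound 2 remains open. The other sugar hydroxyls are free in all three compounds, so acetyl at those places remains unread, and the compounds shown give no reading of this change outside this assay.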